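Series notes: one benzyl replaced by oxan-2-yl

The source may report more compounds than this note shows. Statements on the series, on what has been measured and on what is new or still open speak of the compounds shown alone.

compound 1 `C(#Cc1ncnc2c1ncn2Cc1ccccc1)c1ncnc2c1ncn2Cc1ccccc1`: 5300 nM
compound 2 `CCCCCn1cnc2c(C#Cc3ncnc4c3ncn4CCCCC)ncnc21`: 3000 nM

In a functional assay on L929 cells (Mus musculus) for inhibition (a higher number here means a weaker inhibitor, a lower number a stronger inhibitor), compound 1 gives 5300 nM, the highest of the two numbers. Compound 2 gives 3000 nM, which lies within the scatter of compound 1, so the two cannot be told apart. Compound 3 `C(#Cc1ncnc2c1ncn2C1CCCCO1)c1ncnc2c1ncn2Cc1ccccc1` is not yet measured; it differs from compound 1 by oxan-2-yl in place of benzyl on an aromatic nitrogen. Among the compounds with values here, no step between measured compounds bears on this kind of change, so nothing is known about it here. The step of a 1.1-fold higher number from compound 1 to compound 3 (0.05 log units; within the scatter) is expected to be no larger than the scatter, in either direction. The estimate for compound 3 is 6000 nM, with a range of 2500 nM to 15000 nM.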

Compound 3, half-maximal inhibitory concentration: 1900 nM
Compound 3: the middle estimate sits 3.2-fold (0.50 log units) above what was measured; the measured number lies below the stated range.
By their numbers in this assay, from the lowest: compounds 3, 2 and 1 (each within the scatter of the next, the first and the last beyond it).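

In this assay, oxan-2-yl in place of benzyl on an aromatic nitrogen gives a 2.8-fold lower number from compound 1 to compound 3 (0.45 log units; beyond the scatter) as a modest step beyond the scatter. This position therefore responds to its substituent, and an aromatic ring of carbon only is not needed there on one side of the molecule. No available evidence accounts for this step.

Going by these compounds, whether the ring oxygen of oxan-2-yl matters remains open, and cyclohexyl on the same nitrogen would address that. Also open, on these data alone, is whether oxan-2-yl in place of the remaining benzyl of compound 3 moves the number further.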